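The compounds below may be only part of what the source reports. "The series", "measured", "known", "first", "only" and "open" are said of these compounds alone.

Measured so far, in a functional assay on MDA-MB-231 cells (Homo sapiens) for cytotoxicity, read by MTT assay, with a stated time of 48 h; on this read-out higher numbers stand for weaker inhibition and lower numbers for stronger inhibition:

- compound 1 `O=C(NCc1ccccc1)c1cn(-c2ccccc2)nc1-c1ccncc1`: > 100000 nM
- compound 2 `CCc1ccc(OC(=O)c2cn(-c3ccccc3)nc2-c2ccncc2)cc1`: > 100000 nM
- compound 3 `O=C(Oc1ccc(-c2ccccc2)cc1)c1cn(-c2ccccc2)nc1-c1ccncc1`: > 100000 nM

Each of these values is a limit of the assay, not a measured number. Compound 2 therefore stands at the limit (the limit of > 100000 nM in this assay, at which 3 of the 3 values shown sit), and nothing in the data sets it apart from compound 1 or compound 3.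

Compound 4 `O=C(Oc1ccc2ccccc2c1)c1cn(-c2ccccc2)nc1-c1ccncc1` has not been measured. It differs from compound 2 in one place: naphthalen-2-yl in place of 4-ethylphenyl on an oxygen next to a carbonyl group. For the measured compounds named here, two measured steps touch the same part of the molecule. From compound 1 to compound 2 the step is a step that the two limits leave unreadable from compound 1 to compound 2, and from compound 2 to compound 3 it is a step that the two limits leave unreadable from compound 2 to compound 3. Neither step can be read, since both start and end at the limit; the exchange of ethyl for phenyl on that ring in particular left the result at the limit. For this assay no step beyond the scatter is therefore expected from compound 2 to compound 4, the estimated step being a step that the limit leaves unreadable from compound 2 to compound 4. Compound 4 is expected to give about 150000 nM in this assay, within a range from 40000 nM to 600000 nM, most likely again as a limit rather than a number.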

Compound 4, half-maximal inhibitory concentration: > 100000 nM
Compound 4 was reported as a limit; the forecaster's own chance of this, stated with the estimate: 85%; the middle value does not contradict the limit.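

The step between compound 2 and compound 4 cannot be read, since both values are limits of the assay and not numbers: the limit of > 100000 nM in this assay, at which 4 of the 4 values shown sit.

The compounds shown leave open what change to the shared core, if any, would give a readable number in this assay.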